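Changing the carbonyl substituent of compound 2

This account rests on a few compounds, and the source may have more. Where it says the series, first, only, none or still open, it means among the compounds named here.

- compound 1 `COc1ncc(-c2ccc3ncnc(N[C@H]4CCCN(C(=O)C5CCN(C)CC5)C4)c3c2)cc1C#N`: 420 nM
- compound 2 `COc1ncc(-c2ccc3ncnc(N[C@H]4CCCN(C(=O)CN(C)C)C4)c3c2)cc1C#N`: 160 nM

In a functional assay on SU-DHL-6 cells (Homo sapiens) for antiproliferative activity, read by MTT assay (a higher number here means a weaker inhibitor, a lower number a stronger inhibitor), compound 2 at 160 nM holds the lower of the two numbers, and compound 1 at 420 nM holds the higher. Compound 3 `COc1ncc(-c2ccc3ncnc(N[C@H]4CCCN(C(=O)C5CCNCC5)C4)c3c2)cc1C#N` is still to be measured. It carries piperidin-4-yl in place of (dimethylamino)methyl on a carbonyl carbon and so puts a ring back on that carbonyl.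

Going by the values given here, one measured step bears on this change: a 2.6-fold lower number from compound 1 to compound 2 (0.42 log units; beyond the scatter) with (dimethylamino)methyl replacing 1-methylpiperidin-4-yl at the same carbonyl carbon. Among the compounds with values here, compound 3 has piperidin-4-yl where compound 1 has 1-methylpiperidin-4-yl, and no measured pair isolates that difference, so one step is thin support. Running that step in reverse, a move of similar size towards a higher number is expected in this assay for compound 3. The expected change is a 2.1-fold higher number from compound 2 to compound 3 (0.33 log units; beyond the scatter) and it may prove smaller. The estimated value for compound 3 is 340 nM with 130 nM to 850 nM as its expected range.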

Compound 3, half-maximal inhibitory concentration: 2440 nM
For compound 3 the middle estimate is 7.2-fold (0.86 log units) below the measured one; measured number above the stated range.
By their numbers in this assay, from the lowest: compound 2; then compound 1; then compound 3.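

Going by these compounds alone, compound 1 and compound 3 isolate the substituent on the ring amine nitrogen for the first time, and in this assay the change from methyl to hydrogen gives a 5.8-fold higher number from compound 1 to compound 3 (0.76 log units; beyond the scatter), so a ring on the carbonyl does not set the level of the number alone. The replacement of the open chain gives a 15-fold higher number from compound 2 to compound 3 (1.18 log units; beyond the scatter), which places piperidin-4-yl, with its hydrogen-bond donor, at the high end of this short series, while the ring that keeps its methyl on nitrogen stays much closer to the open-chain (dimethylamino)methyl compound. Nothing available here accounts for either step, and the counted gain of a donor is only a difference between the structures, not an explanation.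

From the compounds shown here alone, what remains open is whether a larger group on the ring nitrogen, such as ethyl or isopropyl, would continue the trend seen on going from hydrogen to methyl, or whether an acetyl on that nitrogen would behave differently from either. On the open-chain side, (methylamino)methyl would show whether losing a methyl from the amine carries a similar penalty outside the ring.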